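This account rests on a few compounds, and the source may have more. Where it says the series, first, only, none or still open, it means among the compounds named here.

In a functional assay on HL-60 cells (Homo sapiens) for inhibition, read by MTT assay, with a stated time of 48 h, tested at 10 uM (a lower number here means less inhibition of growth, a higher number more inhibition of growth at the concentration tested), compound 1 `CCN(CC)Cc1c(O)c([C@H]2CCN(C)C[C@H]2O)c2oc(C)cc(=O)c2c1O` gives 47%, the higher of the two numbers available, and compound 2 `Cc1cc(=O)c2c(O)c(CN3CCC(Cc4ccccc4)CC3)c(O)c([C@H]3CCN(C)C[C@H]3O)c2o1` gives 28%, a gap beyond the scatter. Compound 3 `Cc1cc(=O)c2c(O)c(CN3CCCC3C(=O)O)c(O)c([C@H]3CCN(C)C[C@H]3O)c2o1` is still unmeasured. It differs from compound 1 as follows: 2-carboxypyrrolidin-1-yl in place of diethylamino on a saturated chain carbon bound to an aromatic carbon. Going by the values given here, no measured pair isolates this change, so the expectation is tentative: a downward step in this assay, beyond the scatter, since the only other compound measured, compound 2, gives 28%. The estimated step is a number 25 percentage points lower from compound 1 to compound 3 (beyond the scatter). For compound 3 the expected value is 22%, with an estimated range of 5% to 42%.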

Compound 3, percent growth inhibition at one concentration: 16%
The estimate for compound 3 lay 6 percentage points above the measured number; the range from low to high includes it.
By their numbers in this assay, from the lowest: compound 3; then compound 2; then compound 1.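

In this assay, the pair compound 1 and compound 3 is the only one shown that isolates a single change at this place, and the step of a number 31 percentage points lower from compound 1 to compound 3 (beyond the scatter) shows that the group on this saturated chain carbon bound to an aromatic carbon matters for the read-out. The 2-carboxypyrrolidin-1-yl group brings a ring and a carboxyl group in together. Nothing measured here accounts for the step. The compounds shown leave open which of these two parts goes with the step: unsubstituted pyrrolidin-1-yl, or the methyl ester of the acid, would separate them.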